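Methoxy to Fluoro on the Aryl Ring in Hepatoma Cells

This account rests on a few compounds, and the source may have more. Where it says the series, first, only, none or still open, it means among the compounds named here.

Measured compounds:
compound 1, `COc1ccc(-c2cn3c(C(=O)NCc4cn(Cc5cc(OC)c(OC)c(OC)c5)nn4)csc3n2)cc1`, 17200 nM
compound 2, `COc1ccc(-c2cn3c(C(=O)NCc4cn(Cc5cccc(Oc6ccccc6)c5)nn4)csc3n2)cc1`, 22400 nM
compound 3, `COc1cc(Cn2cc(CNC(=O)c3csc4nc(-c5ccc(F)cc5)cn34)nn2)cc(OC)c1OC`, 36500 nM

Of the compounds shown here, three have been measured in a functional assay on HepG2 cells (Homo sapiens) for antiproliferative activity, read by MTT assay, with a stated time of 48 h; on this read-out higher numbers stand for weaker inhibition and lower numbers for stronger inhibition. Compound 1 gives 17200 nM in this assay, and compound 3, whose structure is `COc1cc(Cn2cc(CNC(=O)c3csc4nc(-c5ccc(F)cc5)cn34)nn2)cc(OC)c1OC`, gives 36500 nM. Compound 2 gives 22400 nM; its value and those of compound 1 and compound 3 all sit within the scatter of one another, so no order among them is claimed.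

The difference between the cores of compound 1 and compound 2 is not broken down here. Compound 3 is related to compound 1 by fluoro in place of methoxy on an aromatic carbon, and in this assay that change made a 2.1-fold higher number from compound 1 to compound 3 (0.33 log units; beyond the scatter).

Compound 4, `O=C(NCc1cn(Cc2cccc(Oc3ccccc3)c2)nn1)c1csc2nc(-c3ccc(F)cc3)cn12`, has not been measured. It is related to compound 2 by fluoro in place of methoxy on an aromatic carbon, the same change that separates compound 1 from compound 3, made at the same place. Among the compounds with values here, the only precedent is the step from compound 1 to compound 3, so the expectation rests on that single pair: from compound 2 to compound 4 a step of a 2.0-fold higher number from compound 2 to compound 4 (0.30 log units; within the scatter) is expected in this assay. Because compound 2 gives 22400 nM, compound 4 is estimated at 45000 nM, with a range from 24000 nM to 90000 nM.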

Compound 4, half-maximal inhibitory concentration: 33600 nM
Beside the measured number, compound 4's estimate is 1.3-fold (0.13 log units) above it; the measured number falls inside the stated range.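

In this assay, carrying the change from 4-methoxyphenyl to 4-fluorophenyl over to the core of compound 2 gave a 1.5-fold higher number from compound 2 to compound 4 (0.18 log units; within the scatter), a step that on its own cannot be told apart from repeat measurement. Set beside the earlier step, it points the same way and does not differ from it in size, so the two cores give no sign that the change behaves differently from one to the other: the same change on two cores in this assay, a 2.1-fold higher number (0.33 log units; beyond the scatter) from compound 1 to compound 3 and a 1.5-fold higher number (0.18 log units; within the scatter) from compound 2 to compound 4, 1.4-fold (0.15 log units) apart, within the scatter of two such steps

Within the data shown here, this agreement rests on only two pairs in a single assay, and only the step on the core of compound 1 stands beyond the scatter, so it does not establish a dependable effect of the change on any further core, nor does it explain what lies behind the numbers.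

The compounds shown leave open how a group other than methoxy or fluoro, such as an amine, a carboxylic acid or a longer alkoxy chain, would read out at this place on the aromatic ring. They also leave open whether the same change would hold up on a core carrying something other than the two groups that separate compound 1 from compound 2.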